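From naphthalen-1-yl to 3,5-difluorophenyl on compound 1

The source may hold more compounds than are shown below. What is called first, only, known or untested is meant among the compounds shown, and "the series" means these compounds.

Within the data shown here, in a functional assay on NIH3T3 cells (Mus musculus) (on this read-out lower numbers stand for an effect already at smaller amounts and higher numbers for an effect only at larger amounts of compound), compound 1 (`Cn1cncc1C(OCc1ccc(C#N)cc1-c1cccc2ccccc12)c1ccc(C#N)nc1`) gives 46 nM, the highest of the three numbers so far. Compound 2 (`Cn1cncc1C(OCc1ccc(C#N)cc1)c1ccc(C#N)c(-c2cccc3cccnc23)c1`) gives 3.7 nM and compound 3 (`Cn1cncc1C(OCc1ccc(C#N)nc1-c1ccc(OC(F)(F)F)cc1)c1ccc(C#N)cc1`) gives 4 nM. These two lie within the scatter of each other, and both lie below compound 1 by more than the scatter.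

Compound 4 (`Cn1cncc1C(OCc1ccc(C#N)cc1-c1cc(F)cc(F)c1)c1ccc(C#N)nc1`) keeps the core of compound 1 and takes 3,5-difluorophenyl in place of naphthalen-1-yl on an aromatic carbon, ortho to a large group and meta to a cyano group: 3,5-difluorophenyl in place of naphthalen-1-yl on an aromatic carbon. Among the measured compounds shown here, no measured pair differs in one place only, so nothing isolates this change. For the measured compounds named here, the only guide is loose: compound 3 also carries a substituted phenyl group and gives 4 nM, though its core differs too. In this assay a modest move toward a lower number is expected, and the estimated step is a 3.1-fold lower number from compound 1 to compound 4 (0.49 log units; beyond the scatter). For compound 4 the estimated value is 15 nM, with an expected range of 4 nM to 50 nM.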

Compound 4, half-maximal effective concentration: 25 nM
Compound 4: middle estimate off by 1.7-fold (0.22 log units), on the low side; low and high end bracket the measured number.
By their numbers in this assay, from the lowest: compounds 2 and 3 (each within the scatter of the next); then compounds 4 and 1 (each within the scatter of the next).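

In this assay, among these compounds, this is the first pair that differs in one place only, and it gives a 1.8-fold lower number from compound 1 to compound 4 (0.26 log units; within the scatter). On this aromatic carbon, ortho to a large group and meta to a cyano group, 3,5-difluorophenyl can therefore take the place of naphthalen-1-yl with no change beyond the scatter, even though two aromatic rings give way to one carrying two fluorines. Nothing available on these compounds speaks to the reason for this result.

The compounds shown leave open how an unsubstituted phenyl would read here, which would separate the loss of the second ring from the entry of the fluorines. Also open, going by these compounds, is how far the read-out would move with a group lacking an aromatic ring on this carbon, such as an amine, a carboxylic acid or a longer alkyl chain.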